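The source may hold more compounds than are shown below. What is called first, only, known or untested is meant among the compounds shown, and "the series" means these compounds.

Among the measured compounds shown here, compound 1 `COc1ccc(-c2cn3ccnc3c(-c3ccc4ncn(C5CCCCC5)c4c3)n2)cc1` is the better of the two compounds measured so far in a functional assay on NCI-H226 cells (Homo sapiens) for inhibition, read by sulforhodamine B assay, with a stated time of 48 h, tested at 10 uM; on this read-out higher numbers stand for more inhibition at the one concentration tested (going by the name of the read-out) and lower numbers for less inhibition. In this assay compound 1 gives 35.9%. For the measured compounds named here, its only measured neighbour is compound 2 `Fc1ccc(-c2cn3ccnc3c(-c3ccc4ncn(C5CCCCC5)c4c3)n2)cc1`, which in this assay gives 23.3%, a step of a number 12.6 percentage points lower from compound 1 to compound 2 (beyond the scatter) that comes from a fluoro in place of methoxy on an aromatic carbon.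

Compound 3 `Brc1ccc(-c2cn3ccnc3c(-c3ccc4ncn(C5CCCCC5)c4c3)n2)cc1` has not yet been measured. It differs from compound 1 by bromo in place of methoxy on an aromatic carbon. Going by the values given here, the one step that bears on this change is the one from compound 1 to compound 2, in which another halogen took the place of the same methoxy group and the inhibition fell by a modest amount, beyond the scatter. Since bromo and fluoro are both halogens entering at the same aromatic carbon, a drop of similar size is expected here, though a halogen of a different size could plausibly land anywhere from no change to a somewhat larger fall.

Compound 3 is therefore expected to give about 25% in this assay, within a range of 10% to 40%, which means an expected step of a number 10.9 percentage points lower from compound 1 to compound 3 (beyond the scatter).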

Compound 3, a percentage reported as inhibition, at one concentration (the size of the read-out at that concentration, not a potency): 23.3%
For compound 3 the middle estimate is 1.7 percentage points above the measured one, and the stated range covers the measured number.
By their numbers in this assay, from the lowest: compounds 2 and 3 (each within the scatter of the next); then compound 1.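

In this assay the change to bromo at this aromatic carbon gives a number 12.6 percentage points lower from compound 1 to compound 3 (beyond the scatter) and so matches the fall seen with fluoro, which shows that the fall is not tied to that one halogen. Among the compounds shown here, the step between the two halogens is no change at the digits printed from compound 2 to compound 3 (within the scatter) and so, at this place para to a large group, the read-out does not separate bromo from fluoro, leaving methoxy as the only one of the three groups that stands apart. Nothing given here accounts for the gap between the methoxy compound and the two halogen compounds.

As far as these compounds go, whether the higher number belongs to methoxy alone or is shared by other groups at this carbon, such as ethoxy, hydroxy, an amine or a plain methyl, remains open. The compounds also leave open whether the same order would hold with something other than the cyclohexyl group that all three carry, and how any of them would behave at other concentrations.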